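Chain variation on the shared core: notes toward compound 4

A few compounds are considered here, and "the series" means these few. Any claim that something is new, unique, unknown or untested is made for them only; others in the source may bear on it.

Compound 1 `Cn1c(=N)sc2cc(OC(F)(F)F)ccc21` gives 5 mg/kg in a functional assay on the whole organism with Rattus norvegicus as the target; a lower number here means that less compound is needed, a higher number that more compound is needed for the effect. Compound 2 `CCn1c(=N)sc2cc(OC(F)(F)F)ccc21` gives 5 mg/kg in this assay; the step of no change at the digits printed from compound 1 to compound 2 (within the scatter) goes with the change (methyl in place of hydrogen on a saturated chain carbon bound to an aromatic nitrogen). Compound 3 `CSCCn1c(=N)sc2cc(OC(F)(F)F)ccc21` gives 1 mg/kg in this assay. The step of a 5.0-fold lower number from compound 1 to compound 3 (0.70 log units; beyond the scatter) goes with the change ((methylsulfanyl)methyl in place of hydrogen on a saturated chain carbon bound to an aromatic nitrogen), and the step of a 5.0-fold lower number from compound 2 to compound 3 (0.70 log units; beyond the scatter) separates compound 3 from compound 2 as well. Compound 3 therefore holds the lowest of the three numbers, with both its steps to compound 1 and compound 2 beyond the scatter; no claim is made beyond these three compounds.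

Compound 4 `CCSCCn1c(=N)sc2cc(OC(F)(F)F)ccc21` has not been measured in this assay. Relative to compound 3 it carries methyl in place of hydrogen on a saturated chain carbon bound to a sulfur. Within the data shown here, this is the same kind of change as the one from compound 1 to compound 2, but it is not the same change: in the earlier case the entering methyl sits on a saturated chain carbon bound to an aromatic nitrogen, whereas in compound 4 it sits on a saturated chain carbon bound to a sulfur. The two cores, that of compound 1 and that of compound 3, differ by (methylsulfanyl)methyl in place of hydrogen on a saturated chain carbon bound to an aromatic nitrogen.

The earlier instance of this kind of change, no change at the digits printed from compound 1 to compound 2 (within the scatter), lay within the scatter. By analogy, the step expected from compound 3 to compound 4 is a 1.2-fold higher number from compound 3 to compound 4 (0.08 log units; within the scatter), resting on the fact that the step of no change at the digits printed from compound 1 to compound 2 (within the scatter) showed no movement at the printed digits. Compound 4 is accordingly estimated at 1.2 mg/kg in this assay. The expected range for compound 4 runs from 0.5 mg/kg to 3 mg/kg, allowing for the surrounding place being different from the earlier instance.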

Compound 4, dose for half-maximal effect: 2.2 mg/kg
Compound 4: middle estimate off by 1.8-fold (0.26 log units), on the low side, within the range that was stated.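

Set side by side in this assay, the methyl change does not read differently on the two cores, as the gap between its two instances stays inside what repeated measurements allow: the same change on two cores in this assay, no change at the digits printed (within the scatter) from compound 1 to compound 2 and a 2.2-fold higher number (0.34 log units; beyond the scatter) from compound 3 to compound 4, 2.2-fold (0.34 log units) apart, within the scatter of two such steps. Taken alone, the newer instance is a 2.2-fold higher number from compound 3 to compound 4 (0.34 log units; beyond the scatter), but this does not show that the core of compound 3 answers methyl differently from the core of compound 1, and two instances also do not show that the change carries over unaltered or set a rule for the series. The ethylsulfanyl chain still keeps the number down relative to the plain chains, with a 2.3-fold lower number from compound 2 to compound 4 (0.36 log units; beyond the scatter) and a 2.3-fold lower number from compound 1 to compound 4 (0.36 log units; beyond the scatter), so within these four compounds the advantage of a sulfur-bearing chain survives the added methyl, with compound 3 holding the lowest number.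

Open, as far as these compounds go, is whether a longer chain on the sulfur, such as propyl or butyl, would extend the movement seen with ethylsulfanyl or leave the number where it stands. Also open, from the compounds shown here alone, is whether the sulfur itself matters, which an ether oxygen, a sulfoxide or a sulfone in its place on the same chain would address.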